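Extending the amine side chain of compound 2

This account rests on a few compounds, and the source may have more. Where it says the series, first, only, none or still open, it means among the compounds named here.

Compound 1 `CCN1CCc2c(sc(NC=O)c2C(N)=O)C1` is the simplest member of the set. In a functional assay (strain AB) with Danio rerio as the target, read by microscopy, with a stated time of 1 h (a higher number here means that more compound is needed for the effect, a lower number that less compound is needed), compound 1 gives only a limit, > 25000 nM. For the measured compounds named here, compound 2 `CCN1CCc2c(sc(NC(=O)Nc3ccc(Cl)cc3)c2C(N)=O)C1` carries (4-chlorophenyl)amino in place of hydrogen on a carbonyl carbon, and in this assay compound 2 gives 3120 nM, the only number among the three values shown. The step of an at least 8.0-fold lower number from compound 1 to compound 2 (0.90 log units; beyond the scatter) is the single gain observed. Compound 3 `CCN1CCc2c(sc(NC(=O)Nc3ccc(Cl)cc3)c2C(=O)NC)C1` carries methyl in place of hydrogen on an amide-type nitrogen, and in this assay compound 3 gives only a limit, > 25000 nM. The step of an at least 8.0-fold higher number from compound 2 to compound 3 (0.90 log units; beyond the scatter) removes that gain entirely. Compound 4 `CC(C)(C)OC(=O)CN1CCc2c(sc(NC(=O)Nc3ccc(Cl)cc3)c2C(N)=O)C1` has not yet been measured; it differs from compound 2 by tert-butoxycarbonyl in place of methyl on a saturated chain carbon bound to an amine nitrogen in a ring. Neither measured step touches the saturated chain carbon bound to the amine nitrogen in the ring; both concern the carbonyl side of the shared core, so they fix only the level from which compound 4 starts. The author therefore expects no step beyond the scatter, a 1.3-fold higher number from compound 2 to compound 4 (0.11 log units; within the scatter). Compound 4 in this assay is estimated at 4000 nM, between 1500 nM and 12000 nM.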

Compound 4, half-maximal effective concentration: > 25000 nM
Compound 4: only a limit was reported (the forecaster's own chance of this, stated with the estimate: 15%); at least 6.2-fold (0.79 log units) between middle value and limit.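

The earlier steps shown here all lay on the carbonyl side of the shared core, so they said nothing about the saturated chain carbon bound to an amine nitrogen in a ring. This change shows that this place also matters in this assay: tert-butoxycarbonyl in place of methyl gives an at least 8.0-fold higher number from compound 2 to compound 4 (0.90 log units; beyond the scatter). Compound 4 gives a limit and not a number, so this step marks only the smallest change consistent with the data, and compound 2 remains the only compound of the four with a number: the limit of > 25000 nM in this assay, at which 3 of the 4 values shown sit.

The true size of the step cannot be read from these data, and a single group cannot show which part of tert-butoxycarbonyl matters. The compounds shown leave open how a carboxylic acid, an amine or a plain longer chain at this place would read out in this assay.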